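This account rests on a few compounds, and the source may have more. Where it says the series, first, only, none or still open, it means among the compounds named here.

Compound 3 `COc1nc(-c2ccc(C(F)(F)F)cc2)ccc1[C@@H](c1ccccc1)[C@@](O)(CCN(C)C)c1cccc2ccccc12` was tested in a toxicity assay on HeLa cells (Homo sapiens) for cytotoxicity; a lower number here means that less compound is tolerated, a higher number that more compound is tolerated. Its value there is a limit of the assay rather than a number: compound 3 gives > 64 ug/mL. Compound 2 `COc1nc(-c2ccc(F)cc2)ccc1[C@@H](c1ccccc1)[C@@](O)(CCN(C)C)c1cccc2ccccc12` carries the same core and also reaches only a limit; in this assay compound 2 gives > 64 ug/mL. Compound 1 `COc1nc(-c2ccccc2F)ccc1[C@@H](c1ccccc1)[C@@](O)(CCN(C)C)c1cccc2ccccc12` completes the set, but in this assay compound 1 gives "nd" (no result reported). Going by the values given here, the one step that can be traced between measured compounds is a step that the two limits leave unreadable from compound 2 to compound 3; because both ends are limits, its size cannot be read. What the numbers do show is the limit of > 64 ug/mL in this assay, at which 2 of the 3 values shown sit, so compound 3 stands where every measured value of the series stands, at the limit.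

Compound 4 `COc1nc(C2CCCCC2)ccc1[C@@H](c1ccccc1)[C@@](O)(CCN(C)C)c1cccc2ccccc12` differs from compound 3 in one place: cyclohexyl in place of 4-(trifluoromethyl)phenyl on an aromatic carbon. No measured step bears on this change, as the only step shown, from compound 2 to compound 3, concerns a different exchange and is itself unreadable. The expectation for compound 4 therefore rests on the observation that the two measured compounds sit at the limit, and the step from compound 3 to compound 4 is expected to be a step that the limit leaves unreadable from compound 3 to compound 4, with none beyond the scatter foreseen. Compound 4 is estimated to give 80 ug/mL in this assay, within a range from 35 ug/mL to 200 ug/mL.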

Compound 4, half-maximal cytotoxic concentration: 57.7 ug/mL
Beside the measured number, compound 4's estimate is 1.4-fold (0.14 log units) above it, within the range that was stated.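

Cyclohexyl on this aromatic carbon, next to the ring nitrogen, gives the first reading of the set that is a number and not a limit: in this assay compound 4 gives 57.7 ug/mL. Measured against the two compounds with a substituted phenyl group at this position, the change amounts to an at least 1.1-fold lower number from compound 3 to compound 4 (0.04 log units; that floor lies within the scatter) and an at least 1.1-fold lower number from compound 2 to compound 4 (0.04 log units; that floor lies within the scatter), so exchanging the aromatic ring for a non-aromatic ring of carbon only is not shown to move the result beyond the normal spread of repeated measurements. These are only minimum sizes, and the true distance stays unknown, because the other end of each step is a limit: the limit of > 64 ug/mL in this assay, at which 2 of the 4 values shown sit.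

The compounds shown leave open whether a numerical reading at this position belongs to cyclohexyl in particular or would also appear with a smaller ring of carbon, such as cyclopentyl, or with a plain methyl group. They also leave open how a group carrying an amine or a carboxylic acid at this position would read in this assay, with the rest of the molecule kept unchanged.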